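This account rests on a few compounds, and the source may have more. Where it says the series, first, only, none or still open, it means among the compounds named here.

In a functional assay on MCF7 cells (Homo sapiens) for inhibition, read by sulforhodamine B assay, with a stated time of 48 h, tested at 50 uM (on this read-out higher numbers stand for more inhibition of growth at the one concentration tested and lower numbers for less inhibition of growth), compound 1 (`COc1ccc([C@@H]2C/C(=N/OCc3cn(-c4ccc(C#N)cc4)nn3)c3cc(CC=C(C)C)c(OC)cc3O2)cc1`) gives 40% and compound 2 (`COc1cc2c(cc1CC=C(C)C)C(=O)C[C@@H](c1ccc(Oc3cccc([N+](=O)[O-])c3)cc1)O2`) gives 53% as the higher of the two numbers. The gap between them lies beyond the usual scatter of such measurements. Going by the values given here, with only two values in hand, compound 2 stands at the top of a very short scale, and little can be read from that position alone.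

Compound 3 (`COc1cc2c(cc1CC=C(C)C)C(=O)C[C@@H](c1ccc(Oc3ccc(Br)cc3)cc1)O2`) has not yet been measured. It keeps the core of compound 2 and differs in one place (4-bromophenyl in place of 3-nitrophenyl on an oxygen on an aromatic ring), with 4-bromophenyl in place of 3-nitrophenyl on an oxygen on an aromatic ring. Among the compounds with values here, no measured pair shows a change of this kind, so the data offer no direct guide to the size of the step. The starting point is therefore compound 2 at 53% and little else.

In this assay a small downward step is expected, none beyond the scatter, and the estimated step (a number 3 percentage points lower from compound 2 to compound 3 (within the scatter)) reflects that expectation. For compound 3 the estimated value is 50% within a wide expected range (33% to 67%).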

Compound 3, percent growth inhibition at one concentration: 68%
Compound 3: middle estimate off by 18 percentage points, on the low side; the whole stated range lies below it.
By their numbers in this assay, from the lowest: compound 1; then compound 2; then compound 3.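

Going by these compounds alone, on the oxygen on an aromatic ring, 4-bromophenyl in place of 3-nitrophenyl gives a number 15 percentage points higher from compound 2 to compound 3 (beyond the scatter) in this assay, the first evidence that this read-out responds to a change at this position, since the earlier compounds offered no pair differing in one place. The step swaps both the substituent and its place on the ring, and the group that leaves has 2 hydrogen-bond acceptors where the one that enters has 0, so a single step cannot say which of these differences matters. Nothing measured here explains the rise in growth inhibition.

A 3-bromophenyl or a 4-nitrophenyl on the same oxygen would separate the substituent from its place on the ring, and these compounds leave that split open. Also open, as far as these compounds go, is whether a 4-chlorophenyl, or a phenyl ring carrying an amine or a carboxylic acid, would match or pass compound 3 at 68% on this shared core, and whether the 4-bromophenyl would have the same effect on the core of compound 1.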